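The source may report more compounds than this note shows. Statements on the series, on what has been measured and on what is new or still open speak of the compounds shown alone.

Working notes on the series. The shared core is that of compound 1 `O=C(NCC1(c2nc(-c3ccccc3)cs2)CCOCC1)c1ccc(-n2cncn2)cc1`. Among the compounds with values here, in a physicochemical assay for solubility, read by chemiluminescence, in phosphate buffer, measured as kinetic solubility, at pH 7.4 (on this read-out higher numbers stand for higher solubility and lower numbers for lower solubility), compound 1 gives 191000 nM, the highest of the two numbers measured so far. Compound 2 `Cn1c(Nc2ccc(C(=O)NCC3(c4nc(-c5ccccc5)cs4)CCOCC3)cc2)nc2ccccc21` carries (1-methyl-1H-benzimidazol-2-yl)amino in place of 1H-1,2,4-triazol-1-yl on an aromatic carbon, and in this assay compound 2 gives 10000 nM; the step is a 19-fold lower number from compound 1 to compound 2 (1.28 log units; beyond the scatter). Within the data shown here, compound 3 `O=C(NCC1(c2nc(-c3ccccc3)cs2)CCOCC1)c1ccc(Nc2ccccn2)cc1` is still to be measured. (pyridin-2-yl)amino in place of 1H-1,2,4-triazol-1-yl on an aromatic carbon The only step that bears on this exchange, a 19-fold lower number from compound 1 to compound 2 (1.28 log units; beyond the scatter), was a large drop for a different amino group entering at the same aromatic carbon, so a lower number is expected for compound 3 in this assay, with the size of the step uncertain since (pyridin-2-yl)amino is not the group measured. The step expected for compound 3 is a 4.8-fold lower number from compound 1 to compound 3 (0.68 log units; beyond the scatter). Compound 3 is estimated at 40000 nM, within a range from 12000 nM to 130000 nM.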

Compound 3, solubility: 12000 nM
The estimate for compound 3 lay 3.3-fold (0.52 log units) above the measured number; the measured number falls inside the stated range.
By their numbers in this assay, from the lowest: compounds 2 and 3 (each within the scatter of the next); then compound 1.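

In this assay, a second amino-linked group at this aromatic carbon, para to a large group, also gives a large drop: a 16-fold lower number from compound 1 to compound 3 (1.20 log units; beyond the scatter), so the drop is not confined to the 1-methyl-1H-benzimidazol-2-yl group. Exchanging that group for pyridin-2-yl on the same nitrogen gives a 1.2-fold higher number from compound 2 to compound 3 (0.08 log units; within the scatter), so this read-out does not separate the two rings, and the step from the 1H-1,2,4-triazol-1-yl group stays large with either one. No measurement at hand bears on the reason for the drop.

Still open, going by these compounds, is whether the lower numbers go with the amino link and its hydrogen, or with the loss of the 1H-1,2,4-triazol-1-yl group itself. A methylamino group, or a pyridine ring joined directly at this aromatic carbon, would bear on that question.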